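The compounds below may be only part of what the source reports. "The series", "measured", "known", "first", "only" and "open" are said of these compounds alone.

Three compounds share one core and differ only in the group carried on the aromatic nitrogen. In a functional assay on FaDu cells (Homo sapiens) for cytotoxicity, read by MTT assay, with a stated time of 72 h (on this read-out lower numbers stand for higher toxicity in this test and higher numbers for lower toxicity in this test), compound 1 `COCC(C)n1cc(C(=O)C(=O)Nc2ccc(OC)nc2)c2ccccc21` gives 12 nM, compound 2 `CCC(C)n1cc(C(=O)C(=O)Nc2ccc(OC)nc2)c2ccccc21` gives 68 nM, and compound 3 `COc1ccc(NC(=O)C(=O)c2cn(CC3CCO3)c3ccccc23)cn1` gives 686 nM. Compound 3 thus has the highest number of the three, the least toxic in this test: the step of a 57-fold higher number from compound 1 to compound 3 (1.76 log units; beyond the scatter) and the step of a 10-fold higher number from compound 2 to compound 3 (1.00 log units; beyond the scatter) both lie beyond the scatter, as does the smaller change a 5.7-fold higher number from compound 1 to compound 2 (0.75 log units; beyond the scatter).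

Compound 4 `COc1ccc(NC(=O)C(=O)c2cn(CCC(=O)O)c3ccccc23)cn1` differs from compound 3 by carboxymethyl in place of oxetan-2-yl on a saturated chain carbon bound to an aromatic nitrogen. For the measured compounds named here, no measured step exchanges a ring for a carboxylic acid, so nothing bears on this change directly. What the data show is that every change of the group on the aromatic nitrogen moved the number by a modest to large amount, and that the two branched groups of compound 1 and compound 2 gave the lowest numbers. Carboxymethyl resembles none of the three measured groups, so the direction of the step is uncertain and the range must be wide; a further move toward higher numbers is the more likely outcome.

Compound 4 is expected to give about 2000 nM in this assay, within 400 nM to 10000 nM. The expected step from compound 3 is a 2.9-fold higher number from compound 3 to compound 4 (0.46 log units; beyond the scatter).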

Compound 4, concentration lethal to 50% of the cells: > 10000 nM
Compound 4: no number, only a limit; the forecaster's own chance of this, stated with the estimate: 15%; middle value at least 5.0-fold (0.69 log units) away from the limit.
By their numbers in this assay, from the lowest: compound 1; then compound 2; then compound 3. At a limit, above all of these: compound 4.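

Compound 4 gives no number in this assay, only a limit, so each step to it marks the smallest possible change: the limit of > 10000 nM in this assay, at which 1 of the 4 values shown sits.

With 2-carboxyethyl on the aromatic nitrogen, the read-out moves by an at least 14-fold higher number from compound 3 to compound 4 (1.16 log units; beyond the scatter), by an at least 140-fold higher number from compound 2 to compound 4 (2.16 log units; beyond the scatter) and by an at least 830-fold higher number from compound 1 to compound 4 (2.92 log units; beyond the scatter), all large and beyond the scatter. For the compounds shown here, the earlier compounds showed that this position responds strongly to the group it carries, with a widest step of a 57-fold higher number from compound 1 to compound 3 (1.76 log units; beyond the scatter), and compound 4 now extends that span further, placing the least toxic result in this test on the one group here that has a carboxylic acid, and so a hydrogen-bond donor, and the shift from a ring to an open chain in a single change.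

That single change leaves the acid and the open chain tangled together: a methyl ester or an amine at the end of the same chain would tell them apart, and a longer chain ending in a carboxylic acid would show how much the chain length matters. As far as these compounds go, how far compound 4 really lies past its limit also stays open.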